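Dimethoxyphenyl for Dichlorophenyl in a Solubility Series

This account rests on a few compounds, and the source may have more. Where it says the series, first, only, none or still open, it means among the compounds named here.

The measured compounds are:
compound 1, `Cc1oc(-c2c(Cl)cccc2Cl)nc1CN1CCC(C(=O)NCCCN2C[C@H](C)C[C@H](C)C2)CC1`, giving > 77 ug/mL in a physicochemical assay for solubility, in phosphate buffer, measured as kinetic solubility, at pH 7.4; a higher number here means a more soluble compound, a lower number a less soluble compound
compound 2, `Cc1ccccc1-c1nc(CN2CCC(C(=O)NCCCN3CCCC(CC(C)C)C3)CC2)c(C)o1`, giving 54.9 ug/mL in this assay

In this assay compound 1 gives > 77 ug/mL, which is a limit of the assay and not a number, as the limit of > 77 ug/mL in this assay, at which 1 of the 2 values shown sits, records. In this assay compound 2 gives 54.9 ug/mL. Among the measured compounds shown here, no step between these two compounds is known, and the two values show only that compound 1 sits at the limit while compound 2 returns a number.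

Compound 3, `COc1cccc(OC)c1-c1nc(CN2CCC(C(=O)NCCCN3C[C@H](C)C[C@H](C)C3)CC2)c(C)o1`, has not yet been measured in this assay. Its difference from compound 1 is 2,6-dimethoxyphenyl in place of 2,6-dichlorophenyl on an aromatic carbon. For this change, the account expects no step beyond the usual scatter in this assay, or at most a small rise. Compound 1 already stands at the limit, so compound 3 is expected to reach the limit as well. Compound 3 is estimated at 90 ug/mL, within a range from 40 ug/mL to 200 ug/mL. The expected step is a step that the limit leaves unreadable from compound 1 to compound 3.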

Compound 3, solubility: > 76 ug/mL
Compound 3: only a limit was reported (the forecaster's own chance of this, stated with the estimate: 60%); the middle value lies beyond the limit too.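

In this assay compound 3 gives > 76 ug/mL, which is a limit of the assay and not a number. Compound 1 gives > 77 ug/mL, also a limit. Among the compounds shown here, no step between compound 1 and compound 3 can be read. The compounds shown leave open whether 2,6-dimethoxyphenyl in place of 2,6-dichlorophenyl shifts solubility at all, and in which direction.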